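Halogen Swap on the Aryl Ring: Cytotoxicity Outlook

A few compounds are considered here, and "the series" means these few. Any claim that something is new, unique, unknown or untested is made for them only; others in the source may bear on it.

Compound 1 `Cc1ccccc1-n1cc(-c2cccc(NS(=O)(=O)c3c[nH]c(=O)[nH]c3=O)c2)nn1`: 21500 nM
Compound 2 `O=c1[nH]cc(S(=O)(=O)Nc2cccc(-c3cn(-c4ccc(F)cc4)nn3)c2)c(=O)[nH]1`: "not toxic" (no number reported)
Compound 3 `O=c1[nH]cc(S(=O)(=O)Nc2ccc(-c3cn(-c4ccccc4F)nn3)cc2)c(=O)[nH]1`: > 100000 nM

For the measured compounds named here, in an ADME assay on GES1 cells (Homo sapiens) for cytotoxicity, read by MTT assay, with a stated time of 24 h (on this read-out lower numbers stand for higher toxicity in this test and higher numbers for lower toxicity in this test), compound 1 gives 21500 nM, the only plain number among the three. Compound 2 is recorded in this assay simply as "not toxic" (no number reported), with no number attached. For compound 3 the test reports only a limit, > 100000 nM. Compound 3 therefore stands at the gentle end of what has been measured, sitting at the limit of > 100000 nM in this assay, at which 1 of the 3 values shown sits, while compound 1 lies clearly on the more toxic side of that limit. No two of these compounds differ in just one place, so no single step has been measured.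

Compound 4 `O=c1[nH]cc(S(=O)(=O)Nc2ccc(-c3cn(-c4ccc(Cl)cc4)nn3)cc2)c(=O)[nH]1` differs from compound 3 by 4-chlorophenyl in place of 2-fluorophenyl on an aromatic nitrogen, in words 4-chlorophenyl in place of 2-fluorophenyl on an aromatic nitrogen. With compound 3 known only as a limit, no direction can be read from the data, and the change is expected to give a step of a number no higher from compound 3 to compound 4 (the limit leaves the size open), nothing beyond the usual scatter. Compound 4 is therefore estimated at 100000 nM, in the range 30000 nM to 300000 nM.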

Compound 4, half-maximal cytotoxic concentration: 23300 nM
The estimate for compound 4 lay 4.3-fold (0.63 log units) above the measured number; measured number below the stated range.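

For the compounds shown here, this pair gives the first single change that can be read in this assay, with an at least 4.2-fold lower number from compound 3 to compound 4 (0.63 log units; beyond the scatter) when 4-chlorophenyl replaces 2-fluorophenyl on the aromatic nitrogen. The group at this position therefore matters in this test: the swap moves the compound towards higher toxicity, beyond the usual scatter. The full size of the step stays unknown because compound 3 is recorded with a limit and not a plain number: the limit of > 100000 nM in this assay, at which 1 of the 4 values shown sits.

The swap changes both the halogen and its place on the phenyl ring, and the compounds shown do not separate these two changes. Going by these compounds, how a phenyl ring carrying an amine or a carboxylic acid would behave at this position also remains open.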